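Chloro for Fluoro: Expected Effect on Growth Inhibition

The source may report more compounds than this note shows. Statements on the series, on what has been measured and on what is new or still open speak of the compounds shown alone.

In a functional assay on SK-MEL-5 cells (Homo sapiens) for inhibition, read by sulforhodamine B assay, with a stated time of 48 h (a lower number here means a stronger inhibitor of growth, a higher number a weaker inhibitor of growth), compound 1 `N=C(N)c1ccc(-c2ccc(-c3cncc4ccccc34)s2)s1` gives 1740 nM. Compound 2 `N=C(N)c1ccc(-c2ccc(-c3ccc(F)cc3)o2)o1` gives 1560 nM in this assay; of the two numbers shown it is the smaller, though its gap to compound 1 lies within the scatter of repeated measurements. Compound 3 `N=C(N)c1ccc(-c2ccc(-c3ccc(Cl)cc3)o2)o1` has not yet been measured. It differs from compound 2 in one place: chloro in place of fluoro on an aromatic carbon. Going by the values given here, no measured pair isolates this change, so its effect here is unknown; only a step not clearly beyond the scatter is expected in this assay. Compound 3 is estimated at 1200 nM, between 500 nM and 3000 nM. The expected step is a 1.3-fold lower number from compound 2 to compound 3 (0.11 log units; within the scatter).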

Compound 3, concentration for 50% growth inhibition: 1810 nM
The estimate for compound 3 lay 1.5-fold (0.18 log units) below the measured number; the measured number falls inside the stated range.
By their numbers in this assay, from the lowest: compounds 2, 1 and 3 (each within the scatter of the next).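

Going by these compounds alone, compounds 2 and 3 form the first measured pair that isolates chloro in place of fluoro on this aromatic carbon, para to a large group, and in this assay the swap gives a 1.2-fold higher number from compound 2 to compound 3 (0.06 log units; within the scatter) on the shared core. At this position, the two halogens therefore cannot be told apart in this assay. Nothing available explains this result.

On these data alone, whether an amine or a carboxylic acid at this position would give a step beyond the scatter remains open. So does whether the same swap would give a similar step on a different core.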